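The source may report more compounds than this note shows. Statements on the series, on what has been measured and on what is new or still open speak of the compounds shown alone.

Measured so far in a functional assay on the whole organism for antagonist activity, with Mus musculus as the target; on this read-out higher numbers stand for an effect only at larger amounts of compound and lower numbers for an effect already at smaller amounts:
- compound 1 `COc1cc(N)c(Cl)cc1NC(=O)C1CCN(Cc2ccc(Cl)cc2)CC1`: 1.2 mg/kg
- compound 2 `COc1cc(N)c(Cl)cc1NC(=O)C1CCN(CC2CCCCCC2)CC1`: only the limit > 10 mg/kg is known.

Compound 2 stands at the limit of this assay, which is a limit and not a number (the limit of > 10 mg/kg in this assay, at which 1 of the 2 values shown sits). Compound 1 gives 1.2 mg/kg in this assay.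

Compound 3 `COc1cc(N)c(Cl)cc1NC(=O)C1CCN(Cc2ccc([N+](=O)[O-])cc2)CC1` differs from compound 2 by 4-nitrophenyl in place of cycloheptyl on a saturated chain carbon bound to an amine nitrogen in a ring. For the measured compounds named here, the only measured step that bears on this change is the one running the other way, from an aromatic six-membered ring to the saturated seven-membered ring on the same carbon: an at least 8.3-fold higher number from compound 1 to compound 2 (0.92 log units; beyond the scatter). Compound 3 puts a substituted phenyl back on that carbon, so the step of an at least 6.6-fold lower number from compound 2 to compound 3 (0.82 log units; beyond the scatter) is expected to go toward a lower number, beyond the scatter, of at least the size of the measured step. Compound 3 is therefore estimated at 1.5 mg/kg, with a range from 0.5 mg/kg to 6 mg/kg.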

Compound 3, dose for half-maximal effect: > 4 mg/kg
Compound 3 was reported as a limit; the forecaster's own chance of this, stated with the estimate: 15%; middle value at least 2.6-fold (0.42 log units) from the limit.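

In this assay, nitro in place of chloro on an aromatic carbon gives an at least 3.3-fold higher number from compound 1 to compound 3 (0.52 log units; beyond the scatter), so a substituted phenyl on this chain carbon does not by itself reach the level of compound 1, and the substituent on the aromatic ring matters to the read-out. Compound 3 stands at a limit, not a number: the limit of > 4 mg/kg in this assay, at which 1 of the 3 values shown sits.

Compound 2 also stands at a limit, and the step from compound 2 to compound 3 cannot be read: the limit of > 10 mg/kg in this assay, at which 1 of the 3 values shown sits.

From the compounds shown here alone, how far compound 3 lies beyond its limit remains open, so the size of the chloro to nitro step is bounded on one side only. Also open, going by these compounds, is whether hydrogen, an amine or a carboxylic acid in place of chloro on an aromatic carbon stays close to compound 1.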